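Oxolanyl carbamate in place of the benzyl amide

The source may report more compounds than this note shows. Statements on the series, on what has been measured and on what is new or still open speak of the compounds shown alone.

Of the compounds shown here, three have been measured in an assay on CHO-K1 cells for displacement of a labelled ligand from prostaglandin E2 receptor EP1 subtype (Homo sapiens); on this read-out lower numbers stand for stronger inhibition and higher numbers for weaker inhibition. Compound 1 `Cc1cc(C(=O)Nc2ccc(F)cc2)nn1Cc1cc(Cl)ccc1OCc1ccccc1` gives 79.4 nM, compound 2 `Cc1cc(C(=O)NCc2ccccc2)nn1Cc1cc(Cl)ccc1OCc1ccccc1` gives 39.8 nM, and compound 3 `Cc1cc(NC(=O)OCC(C)C)nn1Cc1cc(Cl)ccc1OCc1ccccc1` gives 25.1 nM. Compound 2 stands second highest of the three numbers, nearest to compound 3 and furthest from compound 1; the steps of a 2.0-fold lower number from compound 1 to compound 2 (0.30 log units; within the scatter) and a 1.6-fold lower number from compound 2 to compound 3 (0.20 log units; within the scatter) both lie within the scatter, and only a 3.2-fold lower number from compound 1 to compound 3 (0.50 log units; beyond the scatter) exceeds it.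

Compound 4 `Cc1cc(NC(=O)O[C@H]2CCOC2)nn1Cc1cc(Cl)ccc1OCc1ccccc1` is not yet measured. It differs from compound 2 as follows: (((oxolan-3-yl)oxy)carbonyl)amino in place of benzylcarbamoyl on an aromatic carbon. The step that bears most directly is a 1.6-fold lower number from compound 2 to compound 3 (0.20 log units; within the scatter), where a carbamate-type group took the place of the same benzylcarbamoyl group; a 3.2-fold lower number from compound 1 to compound 3 (0.50 log units; beyond the scatter) points the same way. For the measured compounds named here, no measured step contains the oxolan-3-yl ring, so its own contribution is unknown, and the isobutyl of compound 3 is the only carbamate substituent with a number. Compound 4 is therefore expected to show a 1.1-fold lower number from compound 2 to compound 4 (0.06 log units; within the scatter), a step not clearly beyond the scatter. The estimate for compound 4 is 35 nM, with a range from 10 nM to 125 nM.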

Compound 4, half-maximal inhibitory concentration: 79.4 nM
Estimate against measurement, compound 4: 2.3-fold (0.36 log units) below; low and high end bracket the measured number.
By their numbers in this assay, from the lowest: compounds 3, 2, 1 and 4 (each within the scatter of the next, the first and the last beyond it).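

In this assay, the substituent on the oxygen next to a carbonyl group matters: with oxolan-3-yl in place of isobutyl, the result is a 3.2-fold higher number from compound 3 to compound 4 (0.50 log units; beyond the scatter). The carbamate linkage alone therefore does not secure the separation of compound 3 from compound 1, since a 2.0-fold higher number from compound 2 to compound 4 (0.30 log units; within the scatter) and no change at the digits printed from compound 1 to compound 4 (within the scatter) leave compound 4 within the scatter of both amides. No evidence at hand accounts for the step between the isobutyl and oxolan-3-yl carbamates.

The compounds shown leave open whether a cyclopentyl carbamate would stand with compound 3 or with compound 4, which would separate the presence of a ring from that of the ring oxygen. Also open, on these data alone, are the opposite configuration at the oxolan-3-yl stereocentre and a longer chain such as n-hexyl on the carbamate oxygen.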